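This account rests on a few compounds, and the source may have more. Where it says the series, first, only, none or still open, it means among the compounds named here.

Measured so far:
compound 1 `CCOC(=O)c1cnc(N(C)C)n2nc(-c3ccco3)nc12` — in an assay on CHO cells for displacement of a labelled ligand from adenosine receptor A1 (Homo sapiens) (on this read-out higher numbers stand for weaker inhibition and lower numbers for stronger inhibition), compound 1 gives 13400 nM.
compound 2 `CNc1ncc(C(=O)O)c2nc(-c3ccco3)nn12` — in this assay compound 2 gives > 100000 nM, a limit of the assay and not a number.

Compound 2 thus stands at the limit (the limit of > 100000 nM in this assay, at which 1 of the 2 values shown sits); of the two measured compounds it is the one whose inhibition constant could not be resolved, while compound 1 gives a numbered value. Among the measured compounds shown here, no step between compounds differing in one place is available, so the effect of the change to compound 3 `CCCCC(CC)CNc1ncc(C(=O)O)c2nc(-c3ccco3)nn12` rests on the structural change alone: 1-ethylpentyl in place of hydrogen on a saturated chain carbon bound to a nitrogen on an aromatic ring. The acid and the shared core are kept; only the chain at the ring nitrogen grows.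

Expectation: a gain beyond the scatter, the step from an at least 4.0-fold lower number from compound 2 to compound 3 (0.60 log units; beyond the scatter) taken as moderate, toward stronger inhibition, with a fair chance that the assay again returns only a limit. Compound 3 is estimated at 25000 nM, range 3000 nM to 100000 nM.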

Compound 3, inhibition constant: 1780 nM
Estimate against measurement, compound 3: 14-fold (1.15 log units) above; the whole stated range lies above it.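

With the acid and the shared core kept, the saturated chain carbon bound to a nitrogen on an aromatic ring accepts a large addition: 1-ethylpentyl in place of hydrogen gives an at least 56-fold lower number from compound 2 to compound 3 (1.74 log units; beyond the scatter). In this assay compound 3 gives 1780 nM, which shows that a numbered value is reachable with the carboxylic acid in place. In this assay compound 2 gives > 100000 nM, a limit of the assay and not a number, so the step has a lower bound only: the limit of > 100000 nM in this assay, at which 1 of the 3 values shown sits.

The compounds shown leave open whether the gain follows the length of the chain or its branching, which a straight octyl chain or a shorter propyl chain in the same place would help to separate. Also open, on these data alone, is the effect of a primary amide in place of the carboxylic acid with the 1-ethylpentyl group kept.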